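Replacing oxan-4-yl with 2-(diethylamino)ethyl on compound 1

The source may hold more compounds than are shown below. What is called first, only, known or untested is meant among the compounds shown, and "the series" means these compounds.

In a functional assay on RS4-11 cells (Homo sapiens) for inhibition, read by CCK-8 assay, with a stated time of 72 h (on this read-out higher numbers stand for weaker inhibition and lower numbers for stronger inhibition), compound 1 `CC1(C)CCC(CN2CCN(c3ccc(C(=O)NS(=O)(=O)c4ccc(NCC5CCOCC5)c([N+](=O)[O-])c4)c(Oc4cnc5[nH]ccc5c4)c3)CC2)=C(c2ccc(C(F)(F)F)cc2)C1` gives 6.2 nM and holds the lowest of three numbers. Compound 3 `CC1(C)CCC(CN2CCN(c3ccc(C(=O)NS(=O)(=O)c4ccc(NCC5CCOCC5)c([N+](=O)[O-])c4)c(Oc4cnc5[nH]ccc5c4)c3)CC2)=C(c2ccccc2C(F)(F)F)C1` gives 18 nM and compound 2 `CC1(C)CCC(CN2CCN(c3ccc(C(=O)NS(=O)(=O)c4ccc(NCC5CCOCC5)c([N+](=O)[O-])c4)c(Oc4cnc5[nH]ccc5c4)c3)CC2)=C(c2cccc(C(F)(F)F)c2)C1` gives 63 nM on the same read-out. Both carry the trifluoromethyl elsewhere on the phenyl than compound 1 does, and the measured steps are a 2.9-fold higher number from compound 1 to compound 3 (0.46 log units; beyond the scatter) and a 10-fold higher number from compound 1 to compound 2 (1.01 log units; beyond the scatter) in size.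

Compound 4 `CCN(CC)CCCNc1ccc(S(=O)(=O)NC(=O)c2ccc(N3CCN(CC4=C(c5ccc(C(F)(F)F)cc5)CC(C)(C)CC4)CC3)cc2Oc2cnc3[nH]ccc3c2)cc1[N+](=O)[O-]` keeps the 4-(trifluoromethyl)phenyl of compound 1 and differs by 2-(diethylamino)ethyl in place of oxan-4-yl on a saturated chain carbon bound to a nitrogen on an aromatic ring in one place. That is 2-(diethylamino)ethyl in place of oxan-4-yl on a saturated chain carbon bound to a nitrogen on an aromatic ring, which also reads as (oxan-4-yl)methyl to 3-(diethylamino)propyl. Among the compounds with values here, neither measured step touches this place, so they offer no direct guide and show only that a single change here can move the number. A modest rise is therefore expected, and the estimated step is a 2.4-fold higher number from compound 1 to compound 4 (0.38 log units; beyond the scatter) in this assay with wide uncertainty. For compound 4 the estimated value is 15 nM within an expected range of 4 nM to 60 nM in this read-out.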

Compound 4, half-maximal inhibitory concentration: 3 nM
Compound 4: middle estimate off by 5.0-fold (0.70 log units), on the high side, outside the stated range (below it).
By their numbers in this assay, from the lowest: compound 4; then compound 1; then compound 3; then compound 2.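

Until compound 4, only the place of the trifluoromethyl on the phenyl had varied; this change, on a saturated chain carbon bound to a nitrogen on an aromatic ring, gives in this assay a 2.1-fold lower number from compound 1 to compound 4 (0.32 log units; beyond the scatter). The position therefore accepts the loss of the six-membered non-aromatic ring of oxan-4-yl and the entry of the open-chain 2-(diethylamino)ethyl, with its nitrogen in place of the ring oxygen, and the number still falls. No information is available here on what lies behind this shift.

This single pair cannot separate the removal of the ring from the arrival of the amine, so a plain alkyl chain or a piperidine ring at this place would be informative. Going by these compounds, whether the same step holds with 2-(trifluoromethyl)phenyl or 3-(trifluoromethyl)phenyl also remains open.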